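Methoxycarbonyl Analogue of Compound 1: Expected Inhibition

This account rests on a few compounds, and the source may have more. Where it says the series, first, only, none or still open, it means among the compounds named here.

In an assay on HEK293 cells for inhibition of N-acylethanolamine-hydrolyzing acid amidase (Rattus norvegicus), read by LC-MS, with a stated time of 30 min (on this read-out higher numbers stand for weaker inhibition and lower numbers for stronger inhibition), three compounds have been measured so far:
compound 1 `O=C(CCCCCCc1ccccc1)N1CCCC1` gives 12900 nM
compound 2 `Cc1ccc(CCCCCCC(=O)N2CCCC2)cc1` gives 9600 nM
compound 3 `COc1ccc(CCCCCCC(=O)N2CCCC2)cc1` gives 35400 nM

Among these numbers compound 1 stands second highest, with compound 2 nearest and compound 3 furthest away. The step of a 1.3-fold lower number from compound 1 to compound 2 (0.13 log units; within the scatter) lies within the scatter, so compound 1 and compound 2 cannot be told apart on this read-out. The step of a 2.7-fold higher number from compound 1 to compound 3 (0.44 log units; beyond the scatter) is modest but beyond the scatter, and the same holds for a 3.7-fold higher number from compound 2 to compound 3 (0.57 log units; beyond the scatter).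

Compound 4 `COC(=O)c1cccc(CCCCCCC(=O)N2CCCC2)c1` differs from compound 1 by methoxycarbonyl in place of hydrogen on an aromatic carbon. Going by the values given here, no measured step places a group at this position; the two comparisons that bear on it are the methyl and methoxy changes on the same ring in compound 2 and compound 3, one flat within the scatter and one a modest weakening. A methoxycarbonyl is larger than either group, and the one larger, oxygen-bearing change seen here weakened inhibition. The expected step is therefore a 1.9-fold higher number from compound 1 to compound 4 (0.29 log units; within the scatter), a modest weakening with wide uncertainty. Compound 4 is accordingly estimated at 25000 nM, within a range from 8000 nM to 80000 nM.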

Compound 4, half-maximal inhibitory concentration: > 100000 nM
Compound 4: a limit, no number; the forecaster's own chance of this, stated with the estimate: 15%; middle value at least 4.0-fold (0.60 log units) from the limit.
By their numbers in this assay, from the lowest: compounds 2 and 1 (each within the scatter of the next); then compound 3. At a limit, above all of these: compound 4.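

In this assay compound 4 gives > 100000 nM, which is a limit of the read-out and not a number. The earlier compounds shown here carry no group at this place on the ring, and their steps, a 1.3-fold lower number from compound 1 to compound 2 (0.13 log units; within the scatter) and a 2.7-fold higher number from compound 1 to compound 3 (0.44 log units; beyond the scatter), left it unclear how much a substituent could cost; methoxycarbonyl on an aromatic carbon, meta to a large group, now gives an at least 7.7-fold higher number from compound 1 to compound 4 (0.88 log units; beyond the scatter), which exceeds both printed steps in size and shows that this single change can take inhibition out of the measurable range. The step has a lower bound only, and its true size stays unknown, with the reading for compound 4 resting on a single bound: the limit of > 100000 nM in this assay, at which 1 of the 4 values shown sits.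

The compounds shown leave open whether the loss goes with the methoxycarbonyl group itself or with this place on the ring, as neither a methyl nor a methoxy group appears here and methoxycarbonyl appears nowhere else on the ring. Also open, from the compounds shown here alone, is how a carboxylic acid or a primary amide at this same place would read on the core of compound 1.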